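This account rests on a few compounds, and the source may have more. Where it says the series, first, only, none or still open, it means among the compounds named here.

Measured compounds:
Compound 1, `CS(=O)(=O)Nc1ccc(CNC(=O)c2ccc(C34CC(C3)C4)cc2)c(Cl)c1`, gives 17 mL.min-1.g-1.
Compound 2, `CS(=O)(=O)Nc1ccc(CNC(=O)c2ccc(N3CCCC3)cc2)c(Cl)c1`, gives 17 mL.min-1.g-1.
Compound 3, `COC(C)(C)c1ccc(C(=O)NCc2ccc(NS(C)(=O)=O)cc2Cl)cc1`, gives 24 mL.min-1.g-1.

These three compounds share a core and differ only in the group on one aromatic carbon of the benzamide. In an ADME assay on microsomes from liver (Rattus norvegicus, strain Sprague-Dawley) for metabolic stability, read by HPLC, using NADPH, with stated times of 5 min and 60 min, tested at 10 uM (on this read-out lower numbers stand for slow clearance and higher numbers for fast clearance), compound 1 stands level with compound 2 at the digits shown, and the two together hold the lowest numbers of the three; the nearest to compound 1 is compound 2, with no change at the digits printed from compound 1 to compound 2 (within the scatter), and the furthest is compound 3, with a 1.4-fold higher number from compound 1 to compound 3 (0.15 log units; within the scatter). Likewise a 1.4-fold higher number from compound 2 to compound 3 (0.15 log units; within the scatter). Every step in this small set therefore lies within the scatter of repeated measurements.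

Compound 4, `CS(=O)(=O)Nc1ccc(CNC(=O)c2ccc(C(F)(F)C(F)(F)F)cc2)c(Cl)c1`, has not yet been measured in this assay. Relative to compound 1 the change is a group of 7 heavy atoms (2 carbon, 5 fluorine; no ring) in place of a group of 5 heavy atoms (5 carbon; 2 four-membered non-aromatic rings of carbon only), on an aromatic carbon. Going by the values given here, none of the measured steps introduces fluorine, so the bearing of the earlier steps on this one is indirect: they show only that exchanging groups at this position, across three quite different groups, left this assay unchanged within the scatter. On that basis the step is expected to be small, no change at the digits printed from compound 1 to compound 4 (within the scatter), in no particular direction beyond the scatter. Compound 4 is thus estimated at 17 mL.min-1.g-1, with a range from 8 mL.min-1.g-1 to 36 mL.min-1.g-1.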

Compound 4, intrinsic clearance in microsomes: 14 mL.min-1.g-1
The estimate for compound 4 lay 1.2-fold (0.08 log units) above the measured number, and the stated range covers the measured number.
By their numbers in this assay, from the lowest: compounds 4, 1, 2 and 3 (each within the scatter of the next).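

Placing 1,1,2,2,2-pentafluoroethyl on this aromatic carbon, para to a large group, brings fluorine to the position for the first time, and in this assay the exchange gives a 1.2-fold lower number from compound 1 to compound 4 (0.08 log units; within the scatter), so the result seen with the earlier groups extends to a group with no ring and a different atom make-up. The comparisons with the other two groups read the same way, with a 1.2-fold lower number from compound 2 to compound 4 (0.08 log units; within the scatter) and a 1.7-fold lower number from compound 3 to compound 4 (0.23 log units; within the scatter), the second being the widest step in the set and still not beyond the scatter, so none of the four compounds goes against a flat picture at this position. Nothing available explains why the read-out stays so flat across these groups.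

Going by these compounds, whether a carboxylic acid, a primary amine or a hydroxyl on this same carbon would stay within that narrow spread remains open. On these data alone, all four compounds also keep the shared core unchanged, so it is equally open whether this flatness would persist if the chlorine or the methanesulfonyl group elsewhere on the core were replaced.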